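This account rests on a few compounds, and the source may have more. Where it says the series, first, only, none or still open, it means among the compounds named here.

Working notes on the series.

Compound 1 `O=C(CSC(=S)N[C@H]1CCOC1=O)Nc1ccccc1F` and compound 2 `O=C(CSC(=S)N[C@H]1CCOC1=O)Nc1ccc(Cl)cc1` share the same core and differ only in the aryl group on the amide-type nitrogen. In a functional assay on SMMC-7721 cells (Homo sapiens) for cytotoxicity, read by MTT assay, with a stated time of 72 h (a higher number here means a weaker inhibitor, a lower number a stronger inhibitor), compound 1 gives > 128000 nM, which is a limit of the assay and not a number. In this assay compound 2 likewise gives > 128000 nM, again a limit rather than a number. Among the measured compounds shown here, the one step known so far, a step that the two limits leave unreadable from compound 1 to compound 2, is therefore unreadable because of the limit of > 128000 nM in this assay, at which 2 of the 2 values shown sit. For the measured compounds named here, compound 2 thus stands at the limit of the assay, as does the only other value in hand.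

Compound 3 `O=C(CSC(=S)N[C@H]1CCOC1=O)Nc1ccc(Br)cc1` is the next member: bromo in place of chloro on an aromatic carbon. Going by the values given here, the single measured step bears on the position of the aryl substituent rather than on the halogen itself, and its size cannot be read, so no step beyond the scatter is expected in this assay from this exchange of one halogen for another on the same aromatic carbon. The estimated step from compound 2 to compound 3 is a step that the limit leaves unreadable from compound 2 to compound 3. Compound 3 is accordingly expected to give about 200000 nM in this assay, with a range from 60000 nM to 1000000 nM, most likely reported again only as a limit.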

Compound 3, half-maximal inhibitory concentration: 28300 nM
Compound 3: the middle estimate sits 7.1-fold (0.85 log units) above what was measured, and the stated range ends above it.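

Among the compounds shown here, the exchange of one halogen for another on this aromatic carbon, para to a large group, is not neutral in this assay: bromo in place of chloro gives an at least 4.5-fold lower number from compound 2 to compound 3 (0.65 log units; beyond the scatter), and compound 3 is the first member of the series to give a value that is a number and not a limit. The comparison with the 2-fluorophenyl group gives an at least 4.5-fold lower number from compound 1 to compound 3 (0.65 log units; beyond the scatter), so the 4-bromophenyl group stands apart from both other aryl groups shown, although this second step changes the halogen and its place together and cannot separate the two. Both steps are known only as lower bounds, and the step from compound 1 to compound 2 still cannot be read, because the other two compounds sit at a limit of the assay: the limit of > 128000 nM in this assay, at which 2 of the 3 values shown sit.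

Going by these compounds, it remains open whether the step follows bromo alone or would also appear with iodo, methoxy or an amine on the same aromatic carbon. The compounds shown also leave open how much of the value of compound 3 depends on the place of the bromo group on the ring, and whether any aryl group can take the series further.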